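Replacing 4-pentylphenyl with phenethyl: what to expect

The compounds below may be only part of what the source reports. "The series", "measured", "known", "first", "only" and "open" are said of these compounds alone.

Results in a functional assay on SW-620 cells (Homo sapiens) for antiproliferative activity, read by MTT assay, with a stated time of 3 days (on this read-out lower numbers stand for stronger inhibition and higher numbers for weaker inhibition), so far
- Compound 1 `CCCCCCC#Cc1cn(C/C=C/CN2C(=O)c3ccccc3C2=O)c(=O)[nH]c1=O` gives 32000 nM here
- Compound 2 `CCCCCc1ccc(C#Cc2cn(C/C=C/CN3C(=O)c4ccccc4C3=O)c(=O)[nH]c2=O)cc1` gives 30000 nM here

Going by the values given here, only two numbers exist, and compound 2 stands together with compound 1 rather than apart from it. Putting 4-pentylphenyl in place of hexyl on a triple-bonded carbon gave a 1.1-fold lower number from compound 1 to compound 2 (0.03 log units; within the scatter) and so left no real difference between them.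

Compound 3 `O=C1c2ccccc2C(=O)N1C/C=C/Cn1cc(C#CCCc2ccccc2)c(=O)[nH]c1=O` is the next to be tested. It keeps the shared core and changes that same place, with phenethyl in place of 4-pentylphenyl on a triple-bonded carbon, as phenethyl in place of 4-pentylphenyl on a triple-bonded carbon sets out in full.

Among the compounds with values here, the only guide is the earlier exchange at this place, and with a result of a 1.1-fold lower number from compound 1 to compound 2 (0.03 log units; within the scatter) it gives no reason to expect a large shift in this assay in either direction. A single step is thin evidence, so the range is kept wide. The expected step, no larger than the scatter, is no change at the digits printed from compound 2 to compound 3 (within the scatter) for now. Compound 3 is estimated at 30000 nM with an expected range from 12000 nM to 70000 nM once measured.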

Compound 3, half-maximal inhibitory concentration: 11000 nM
Compound 3: the middle estimate sits 2.7-fold (0.44 log units) above what was measured; measured number below the stated range.
By their numbers in this assay, from the lowest: compound 3; then compounds 2 and 1 (each within the scatter of the next).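

This position on the triple-bonded carbon can respond in this assay: the phenethyl exchange gave a 2.7-fold lower number from compound 2 to compound 3 (0.44 log units; beyond the scatter), a modest step but one beyond the scatter, whereas compound 1 and compound 2, with hexyl and 4-pentylphenyl, could not be told apart. Compound 3 also separates from the hexyl compound, with phenyl in place of butyl on a saturated chain carbon, two bonds along the chain from a triple-bonded carbon, giving a 2.9-fold lower number from compound 1 to compound 3 (0.46 log units; beyond the scatter), so among these three compounds only the phenethyl group stands apart. Phenethyl has 8 heavy atoms, fewer than 4-pentylphenyl, and the same count of one six-membered aromatic ring, but no measurement here explains why this exchange lowered the number.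

As far as these compounds go, with a single compound carrying phenethyl, it remains open whether the link between the triple-bonded carbon and the ring matters most, which a benzyl group or a longer phenylpropyl chain would help to test. From the compounds shown here alone, it is also open whether an amine or a carboxylic acid on the phenyl ring of phenethyl would lower the number further, leave it unchanged or raise it.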